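Lengthening the Amide Chain of Compound 1

The compounds below may be only part of what the source reports. "The series", "measured", "known", "first", "only" and "open" are said of these compounds alone.

In an ADME assay on cells (Fibroblast) for antiproliferative activity, read by sulforhodamine B assay, with a stated time of 48 h (a higher number here means a weaker inhibitor, a lower number a stronger inhibitor), compound 1 (`CCCCCCCCCCNC(=O)c1c[nH]c(-c2ccccc2)n1`) stands at "not determined" (no result reported) and so offers no number as a starting point. Going by the values given here, compound 2 (`CCCCCCCCCCCCCCNC(=O)c1c[nH]c(-c2ccccc2)n1`) gives 42700 nM in this assay and is the only measured value. Compound 3 (`CCCCCCCCCCCCCCCCCCNC(=O)c1c[nH]c(-c2ccccc2)n1`) differs from compound 1 by octyl in place of hydrogen on a saturated chain carbon, ten or more bonds along the chain from an amide-type nitrogen and this means octyl in place of hydrogen on a saturated chain carbon, ten or more bonds along the chain from an amide-type nitrogen. Among the compounds with values here, no measured step exists, so with compound 2 at 42700 nM as the sole guide, no shift beyond the usual scatter is expected in this assay for the longer chain. Compound 3 is estimated at 40000 nM with an expected range from 12000 nM to 100000 nM as the likely span.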

Compound 3, half-maximal inhibitory concentration: 47400 nM
Beside the measured number, compound 3's estimate is 1.2-fold (0.07 log units) below it; measured number inside the range.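

In this assay, lengthening the amide chain gives a 1.1-fold higher number from compound 2 to compound 3 (0.05 log units; within the scatter). Going by these compounds alone, this is the first step that can be read at this position, and it shows that the added carbons leave the read-out within the scatter. No evidence on hand offers an explanation for this result.

Steps from compound 1 cannot be read, so its shorter chain stays unplaced. The compounds shown leave open whether an amine or a carboxylic acid at the chain end would shift the number beyond the scatter.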